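The compounds below may be only part of what the source reports. "The series", "measured", "known", "first", "only" and "open" are said of these compounds alone.

Compound 2 `COc1cc2c(Nc3nc4ccc(C(=O)Nc5c(C)cccc5C)cc4s3)ncnc2cc1OCCCN1CCCCC1` gives the lower of the two numbers in a functional assay on U-937 cells (Homo sapiens) for cytotoxicity, read by WST assay, with a stated time of 72 h (on this read-out lower numbers stand for stronger inhibition and higher numbers for weaker inhibition), at 14700 nM. For the measured compounds named here, compound 1 `CCN(CC)CCCOc1cc2ncnc(Nc3nc4ccc(C(=O)Nc5c(C)cccc5C)cc4s3)c2cc1OC` gives 23700 nM in this assay, and the only measured step, a 1.6-fold lower number from compound 1 to compound 2 (0.21 log units; within the scatter), lies within the scatter. Compound 3 `COc1cc2c(Nc3nc4ccc(C(=O)Nc5c(C)cccc5C)cc4s3)ncnc2cc1OCCCN1CCC(C)CC1` differs from compound 2 by methyl in place of hydrogen on a saturated ring carbon. Going by the values given here, no measured pair shows a methyl added to a ring of this kind, and the one step on the amine end was small, so the estimate for compound 3 is a 1.0-fold higher number from compound 2 to compound 3 (0.01 log units; within the scatter), no change beyond the scatter. Compound 3 is therefore expected near 15000 nM, between 6000 nM and 40000 nM.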

Compound 3, half-maximal inhibitory concentration: 11200 nM
For compound 3 the middle estimate is 1.3-fold (0.13 log units) above the measured one; the range from low to high includes it.
By their numbers in this assay, from the lowest: compounds 3, 2 and 1 (each within the scatter of the next, the first and the last beyond it).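

In this assay, methyl on the saturated ring carbon three ring bonds from the ring nitrogen gives a 1.3-fold lower number from compound 2 to compound 3 (0.12 log units; within the scatter) and so stays within the scatter at this position. For the compounds shown here, replacing diethylamino with 4-methylpiperidin-1-yl gives a 2.1-fold lower number from compound 1 to compound 3 (0.33 log units; beyond the scatter) and is the first step at the amine end to pass the scatter, though only modestly. No evidence bearing on either step is available.

Open, going by these compounds, are other ring amines, such as morpholin-4-yl or 4-methylpiperazin-1-yl, at this chain end. On these data alone, a longer chain to the amine also remains open.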